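A Double Bond Flipped from E to Z

This account rests on a few compounds, and the source may have more. Where it says the series, first, only, none or still open, it means among the compounds named here.

Compound 2 `CC1=C(O)/C(=C\[C@H](C)CCC/C(C)=C/CCc2coc(Cc3ccoc3)c2)OC1=O` gives the lowest of the two numbers measured in a functional assay on A549 cells (Homo sapiens) for cytotoxicity (a lower number here means that less compound is needed, a higher number that more compound is needed for the effect), at 4.98 ug/mL. Compound 1 `CC1=C(O)[C@@H](C/C(C)=C\CCC(C)/C=C/C=C(\C)CCCc2ccoc2)OC1=O` needs more, giving 29.7 ug/mL in this assay, a gap beyond the scatter. Compound 3 `CC1=C(O)/C(=C/[C@H](C)CCC/C(C)=C/CCc2coc(Cc3ccoc3)c2)OC1=O` is the next compound to be measured. (the two compounds have the same atoms and bonds and differ only in configuration as drawn: 1 of 3 stereo elements differ; a double bond is drawn E in compound 2 and Z in compound 3). Among the compounds with values here, no pair of measured compounds shows what such a change alone does, so the step is expected to be small, in either direction, or none beyond the scatter. Compound 3 is therefore expected to give about 7 ug/mL in this assay, with a range from 2.5 ug/mL to 20 ug/mL. That estimate means an expected step of a 1.4-fold higher number from compound 2 to compound 3 (0.15 log units; within the scatter).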

Compound 3, concentration for half-maximal effect: 3.72 ug/mL
The estimate for compound 3 lay 1.9-fold (0.27 log units) above the measured number; the measured number falls inside the stated range.
By their numbers in this assay, from the lowest: compounds 3 and 2 (each within the scatter of the next); then compound 1.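

Within the data shown here, this is the first direct view of what the geometry of this double bond does, and the comparison is a clean one: the fact that compounds 2 and 3 differ only in the configuration as drawn. In this assay, the step is a 1.3-fold lower number from compound 2 to compound 3 (0.13 log units; within the scatter), so E and Z cannot be told apart at this position in this read-out. A cell-killing effect of this size therefore does not depend on how this double bond is drawn.

From the compounds shown here alone, whether the other two stereo elements matter as little stays open. So does the effect of adding an amine or a carboxylic acid to the side chain.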